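Carboxy in place of methoxy on compound 1

The source may report more compounds than this note shows. Statements on the series, on what has been measured and on what is new or still open speak of the compounds shown alone.

In a functional assay for inhibition, with Homo sapiens as the target (a lower number here means a stronger inhibitor, a higher number a weaker inhibitor), compound 1 (`COc1cccc(/C=C/C(=O)c2c(OC)cc(OC)cc2OC)c1`) gives 1800 nM and stands highest of the two numbers, while compound 2 (`COc1cc(OC)c(C(=O)/C=C/c2ccncc2)c(OC)c1`) gives 592 nM as its value. Compound 3 (`COc1cc(OC)c(C(=O)/C=C/c2cccc(C(=O)O)c2)c(OC)c1`) differs from compound 1 by a single change (carboxy in place of methoxy on an aromatic carbon), carboxy in place of methoxy on an aromatic carbon. Among the measured compounds shown here, the only measured step (a 3.0-fold lower number from compound 1 to compound 2 (0.48 log units; beyond the scatter)) replaced the whole 3-methoxyphenyl with pyridin-4-yl, so it bears on this change only indirectly and offers a modest size as a guide. For the measured compounds named here, a modest estimated step (a 2.2-fold higher number from compound 1 to compound 3 (0.35 log units; beyond the scatter)) toward a higher number is expected, although no measured compound fixes its direction. For compound 3 the expected value is 4000 nM with an estimated range from 900 nM to 15000 nM around it.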

Compound 3, half-maximal inhibitory concentration: 6760 nM
Beside the measured number, compound 3's estimate is 1.7-fold (0.23 log units) below it, and the stated range covers the measured number.
By their numbers in this assay, from the lowest: compound 2; then compound 1; then compound 3.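

In this assay, among the compounds shown here, carboxy in place of methoxy on the aromatic carbon gives a 3.8-fold higher number from compound 1 to compound 3 (0.57 log units; beyond the scatter), the first measured change at this single position, with the rest of the core of compound 1 held fixed. The earlier step had replaced the whole 3-methoxyphenyl, whereas this one shows that swapping one group on that ring is enough to move the number upward. No measurement available here accounts for the rise. The compounds shown leave open how a primary amide or a methyl ester would read at this same place, and whether a hydroxyl would stand closer to methoxy or to carboxy.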